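Two fluorines for a biphenyl: estimating compound 4

The source may hold more compounds than are shown below. What is called first, only, known or untested is meant among the compounds shown, and "the series" means these compounds.

Compound 1 `CC(C)[C@H](NC(=O)COc1cccc2ccccc12)C(=O)N[C@@H](CC(=O)O)C(=O)COc1ccc(-c2ccccc2)cc1` is the weakest of the three measured compounds in a functional assay with Homo sapiens as the target (a higher number here means a weaker inhibitor, a lower number a stronger inhibitor), where compound 1 gives 38700 nM. Compound 2 `CC(C)[C@H](NC(=O)COc1cccc2ccccc12)C(=O)N[C@@H](CC(=O)O)C(=O)COc1cccc(F)c1` gives 12000 nM and compound 3 `CC(C)[C@H](NC(=O)COc1cccc2ccccc12)C(=O)N[C@@H](CC(=O)O)C(=O)COc1ccc(F)cc1` gives 14300 nM. Compound 4 `CC(C)[C@H](NC(=O)COc1cccc2ccccc12)C(=O)N[C@@H](CC(=O)O)C(=O)COc1ccc(F)cc1F` is not yet measured; it differs from compound 1 by 2,4-difluorophenyl in place of 4-phenylphenyl on an oxygen on a saturated carbon. Among the compounds with values here, two measured steps bear on this change. Replacing the same group by a single fluorophenyl gave a 3.2-fold lower number from compound 1 to compound 2 (0.51 log units; beyond the scatter) and swapping fluoro for phenyl gave a 2.7-fold lower number from compound 1 to compound 3 (0.43 log units; beyond the scatter), while between compound 2 and compound 3 there is a 1.2-fold higher number from compound 2 to compound 3 (0.08 log units; within the scatter). A modest step downward is therefore expected for compound 4, about a 3.5-fold lower number from compound 1 to compound 4 (0.55 log units; beyond the scatter). Compound 4 is estimated at 11000 nM in this assay, within a range of 5000 nM to 25000 nM.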

Compound 4, half-maximal inhibitory concentration: 17600 nM
For compound 4 the middle estimate is 1.6-fold (0.20 log units) below the measured one, and the stated range covers the measured number.
By their numbers in this assay, from the lowest: compounds 2, 3 and 4 (each within the scatter of the next); then compound 1.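

In this assay, a third fluorinated ring also gives a lower number than the 4-phenylphenyl group, with a 2.2-fold lower number from compound 1 to compound 4 (0.34 log units; beyond the scatter). A second fluoro on the ring brings no change that can be told apart from the scatter, with a 1.2-fold higher number from compound 3 to compound 4 (0.09 log units; within the scatter), and the 2,4-difluorophenyl and 3-fluorophenyl groups also cannot be separated, with a 1.5-fold higher number from compound 2 to compound 4 (0.17 log units; within the scatter). No measurement offers an explanation for these results.

Still open, going by these compounds, is how a plain phenyl group would compare at this oxygen. So is whether an amine or a carboxylic acid on the ring would shift the number further.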